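A few compounds are considered here, and "the series" means these few. Any claim that something is new, unique, unknown or untested is made for them only; others in the source may bear on it.

Working notes on the series.

Compound 1 `CO[C@H]1C(=O)N2C(C(=O)C(C)(C)C)=C(C)C(Sc3nnc(C)s3)S(=O)(=O)[C@H]12` and compound 2 `CO[C@H]1C(=O)N2C(C(=O)C(C)(C)C)=C(C)C(Sc3nnnn3C)S(=O)(=O)[C@H]12` share one core; compound 3 `CO[C@H]1C(=O)N2C(C(=O)C(C)(C)C)=C(CSc3nnc(C)s3)CS(=O)(=O)[C@H]12` and compound 4 `CO[C@H]1C(=O)N2C(C(=O)C(C)(C)C)=C(CSc3nnnn3C)CS(=O)(=O)[C@H]12` share another, the same atoms joined differently. The difference between the two cores is not broken down here.

In a physicochemical assay for pharmacokinetics, at 37 degrees C (a lower number here means that the compound disappears faster, a higher number that the compound lasts longer), compound 1 gives 26 h. Compound 2 gives 14.8 h in this assay. The change between them is 1-methyl-1H-tetrazol-5-yl in place of 5-methyl-1,3,4-thiadiazol-2-yl on a sulfur, and the step it made is a 1.8-fold lower number from compound 1 to compound 2 (0.24 log units; within the scatter).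

Compound 3 gives 37 h in this assay, close to compound 1 and further from compound 2.

Compound 4 carries 1-methyl-1H-tetrazol-5-yl in place of 5-methyl-1,3,4-thiadiazol-2-yl on a sulfur. This is the same kind of change as that from compound 1 to compound 2, not the same: there the sulfur's other neighbour is a saturated ring carbon, here it is a saturated chain carbon.

Going by the values given here, for compound 4 the expected step is a 1.8-fold lower number from compound 3 to compound 4 (0.25 log units; within the scatter), resting on compound 1 to compound 2, because a 1.8-fold lower number from compound 1 to compound 2 (0.24 log units; within the scatter) is the only measured instance of this kind of change. Compound 4 is therefore estimated at 21 h, with a range from 12 h to 35 h.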

Compound 4, half-life: 24 h
For compound 4 the middle estimate is 1.1-fold (0.06 log units) below the measured one; low and high end bracket the measured number.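

In this assay, 1-methyl-1H-tetrazol-5-yl in place of 5-methyl-1,3,4-thiadiazol-2-yl on a sulfur whose other neighbour is a saturated chain carbon gives a 1.5-fold lower number from compound 3 to compound 4 (0.19 log units; within the scatter), and on a saturated ring carbon in the other core it gives a 1.8-fold lower number from compound 1 to compound 2 (0.24 log units; within the scatter). Both steps lie within the scatter, so across these two pairs the change stays too small to read on either core; this does not show that it has a real effect, or that a larger effect would carry from one core to the other. The data on hand offer no measurement that could account for the half-lives.

With only these two groups on the sulfur, two pairs give little basis for a general rule about this position. Still open, from the compounds shown here alone, is how the half-life responds on each core when the sulfur carries a ring bearing a carboxylic acid or an amine, or a simple butyl chain instead of an aromatic ring.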